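A few compounds are considered here, and "the series" means these few. Any claim that something is new, unique, unknown or untested is made for them only; others in the source may bear on it.

Compound 1 `Cc1cnn(-c2ccc(C)nc2C(=O)N2CC3(CC3)C[C@H]2CNc2ccc(C(F)(F)F)cn2)c1`: 8.9
Compound 2 `Cc1cccc(NC[C@@H]2CC3(CC3)CN2C(=O)c2nc(C)sc2-c2ccccc2)n1`: 7.3
Compound 3 `Cc1nc(C(=O)N2CCC3(CC3)C[C@H]2CNc2ccc(C(F)(F)F)cn2)c(-c2ccccc2)s1`: 7.7

All three compounds were tested in a functional assay on CHO cells for antagonist activity at Orexin/Hypocretin receptor type 1 (Homo sapiens), read by FLIPR and calcium flux; on this read-out higher numbers stand for higher potency (the scale is a negative logarithm) and lower numbers for lower potency. Compound 1 gives the highest number of the three, 8.9. Compound 3 comes nearest with 7.7, a gap that lies beyond the scatter of repeated measurements, and compound 2 lies furthest with 7.3, also beyond the scatter. No two of the measured compounds differ in only one place, so no single structural change has been measured directly in this set.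

Compound 4 `Cc1ccc(-c2ncccn2)c(C(=O)N2CC3(CC3)C[C@H]2CNc2ccc(C(F)(F)F)cn2)n1` has not yet been measured. It differs from compound 1 in one place: pyrimidin-2-yl in place of 4-methyl-1H-pyrazol-1-yl on an aromatic carbon. One small aromatic ring is exchanged for another of the same size, and the rest of compound 1 is kept unchanged. Without a measured step to set the size, the expectation is a change that stays within or close to the scatter, if anything slightly downward, so the expected step is a number 0.30 log units lower from compound 1 to compound 4 (within the scatter). Compound 4 is thus estimated at 8.6 in this assay, with a range from 7.9 to 9.2.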

Compound 4, negative logarithm of the antagonist equilibrium constant: 8.4
Compound 4: middle estimate off by 0.20 log units, on the high side; the range from low to high includes it.
By their numbers in this assay, from the lowest: compound 2; then compound 3; then compound 4; then compound 1.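

In this assay, among these compounds, the exchange of 4-methyl-1H-pyrazol-1-yl for pyrimidin-2-yl gives the first single-place comparison in this set: a number 0.50 log units lower from compound 1 to compound 4 (beyond the scatter). The two groups have the same counts of heavy atoms, hydrogen-bond donors and hydrogen-bond acceptors, yet this position, on an aromatic carbon ortho to a large group, still distinguishes between them by a modest step. Nothing measured here explains that difference.

This one exchange replaces a five-membered aromatic ring with a six-membered one and also removes the methyl group, so the compounds shown cannot separate those two changes. An unsubstituted pyrazol-1-yl or a 1,2,3-triazol-2-yl at this position would be needed to tell whether the ring size, the methyl group or both account for the step.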